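Working notes: side-chain change from compound 2 to compound 3

The source may report more compounds than this note shows. Statements on the series, on what has been measured and on what is new or still open speak of the compounds shown alone.

Two compounds carry numbers in a functional assay on the whole organism with Rattus norvegicus as the target, at a dose of 100 mg/kg; a higher number here means more inhibition at the dose given (going by the name of the read-out), a lower number less inhibition. Compound 1 `C/N=C(/NC#N)NCCCn1nc(-c2ccccc2)ccc1=O` gives 40.5% in this assay. Compound 2 `CN(C)/C(=N/CCCCn1nc(-c2ccccc2)ccc1=O)NC#N` gives 80.7% and stands highest of the two, its distance to compound 1 lying beyond the usual scatter. Compound 3 `CC/N=C(\S)NCCCCCn1nc(-c2ccccc2)ccc1=O` awaits measurement; it differs from compound 2 by a group of 7 heavy atoms (4 carbon, 2 nitrogen, 1 sulfur; no ring) in place of a group of 8 heavy atoms (4 carbon, 4 nitrogen; no ring), on a saturated chain carbon, four bonds along the chain from an aromatic nitrogen. Going by the values given here, no step between measured compounds covers this change, so the direction rests on compound 2 alone. A downward step beyond the scatter is expected, a number 25.7 percentage points lower from compound 2 to compound 3 (beyond the scatter). Compound 3 is expected near 55%, within 25% to 85%.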

Compound 3, a percentage reported as inhibition, in the whole organism at one dose (the size of the read-out at that dose, not a potency): 66.4%
Estimate against measurement, compound 3: 11.4 percentage points below, within the range that was stated.
By their numbers in this assay, from the lowest: compound 1; then compound 3; then compound 2.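

In this assay the group of 7 heavy atoms (4 carbon, 2 nitrogen, 1 sulfur; no ring) retains much of the read-out at this place, but the replacement still costs, with a number 14.3 percentage points lower from compound 2 to compound 3 (beyond the scatter) on this side chain. Against the shorter side chain the direction reverses, with a number 25.9 percentage points higher from compound 1 to compound 3 (beyond the scatter), which puts compound 3 in the middle of the three. No measured evidence bearing on either step is available.

Going by these compounds, each step changes the whole group, so the part of it that carries the difference stays open. On these data alone, how a carboxylic acid at the end of the chain would read also stays open.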